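Notes on replacing carbamoyl with vinyloxy in a two-compound series

The source may hold more compounds than are shown below. What is called first, only, known or untested is meant among the compounds shown, and "the series" means these compounds.

Within the data shown here, compound 2 `NC(=O)c1cncc(N2CCCNCC2)c1` holds the lower of the two numbers measured so far. In an assay on HEK293 cells with Neuronal acetylcholine receptor; alpha4/beta2 (Homo sapiens) as the target, read by FLIPR and calcium flux (on this read-out higher numbers stand for larger maximal responses and lower numbers for smaller maximal responses), compound 2 gives 56%, while compound 1 `COc1cncc(N2CCCNCC2)c1` gives 66%; the step of a number 10 percentage points lower from compound 1 to compound 2 (within the scatter) stays within the scatter, so the two cannot be ranked against each other. Compound 3 `C=COc1cncc(N2CCCNCC2)c1` has not yet been measured. The change is vinyloxy in place of carbamoyl on an aromatic carbon. Among the measured compounds shown here, only one measured step bears on this position, the exchange from compound 1 to compound 2, and it was small. Compound 3 carries an oxygen-linked group as compound 1 does, so for compound 3 a step of a number 6 percentage points higher from compound 2 to compound 3 (within the scatter) is expected, essentially a return toward the level of compound 1, and not beyond the scatter. For the measured compounds named here, the estimate for compound 3 is therefore 62%, with a range from 45% to 80%, wide because the basis is the single step of a number 10 percentage points lower from compound 1 to compound 2 (within the scatter).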

Compound 3, largest response reached (reported as efficacy), in percent of the reference or control that the assay uses: 61%
Estimate against measurement, compound 3: 1 percentage points above, within the range that was stated.
By their numbers in this assay, from the lowest: compounds 2, 3 and 1 (each within the scatter of the next).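

In this assay the exchange of vinyloxy for carbamoyl on an aromatic carbon gives a number 5 percentage points higher from compound 2 to compound 3 (within the scatter) and the exchange of vinyl for methyl on the oxygen gives a number 5 percentage points lower from compound 1 to compound 3 (within the scatter) and so neither step separates the compounds. Compound 1, compound 2 and compound 3 therefore cannot be ranked, and the loss of the hydrogen-bond donor of carbamoyl comes with no step beyond the scatter at this position. No measured finding available here offers a reason for these numbers.

On these data alone, it stays open whether an amine, a carboxylic acid or a longer alkoxy chain at this position would shift the maximal response beyond the scatter. As far as these compounds go, it also stays open whether the same groups would behave alike on another aromatic carbon of the shared core.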